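Chain homologation at two sites in a cytotoxicity series

The source may report more compounds than this note shows. Statements on the series, on what has been measured and on what is new or still open speak of the compounds shown alone.

Compound 1 `CCOC(=O)c1c(C)coc1-c1ccc2c(CC)cccc2c1OC` and compound 2 `CCCOC(=O)c1c(C)coc1-c1ccc2c(CC)cccc2c1OC` share one core and differ by methyl in place of hydrogen on a saturated chain carbon, two bonds along the chain from an oxygen next to a carbonyl group. In a functional assay on SK-BR-3 cells (Homo sapiens) for cytotoxicity, read by MTT assay, with a stated time of 72 h (on this read-out lower numbers stand for an effect already at smaller amounts and higher numbers for an effect only at larger amounts of compound), compound 1 gives 2.5 ug/mL. Compound 2 reaches only a limit of the assay, > 10 ug/mL. Read as a step this is an at least 4.0-fold higher number from compound 1 to compound 2 (0.60 log units; beyond the scatter). Compound 3 `CCc1cccc2c(OC)c(-c3occ(C)c3COC)ccc12` carries another group on the core of compound 1, namely (methoxymethyl in place of ethoxycarbonyl on an aromatic carbon). In this assay compound 3 also sits at a limit, > 10 ug/mL. Across the set stands (the limit of > 10 ug/mL in this assay, at which 2 of the 3 values shown sit). Compound 4 `CCOc1c(-c2occ(C)c2COC)ccc2c(CC)cccc12` is still to be measured; it differs from compound 3 by methyl in place of hydrogen on a saturated chain carbon bound to an oxygen on an aromatic ring. This is the same kind of change as that between compound 1 and compound 2, but the place is not the same: there it sat on a saturated chain carbon, two bonds along the chain from an oxygen next to a carbonyl group, here on a saturated chain carbon bound to an oxygen on an aromatic ring. The measured step of an at least 4.0-fold higher number from compound 1 to compound 2 (0.60 log units; beyond the scatter) ran toward higher numbers. Compound 3 starts from a limit. For compound 4 in this assay the expected step is a step that the limit leaves unreadable from compound 3 to compound 4. The estimated value for compound 4 is 14 ug/mL, with a range from 4 ug/mL to 50 ug/mL, and most probably the assay will again report only a limit.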

Compound 4, concentration for half-maximal effect: > 10 ug/mL
Compound 4: no number, only a limit; the forecaster's own chance of this, stated with the estimate: 80%; the middle value lies beyond the limit too.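

In this assay compound 3 and compound 4 both rest only at a limit of the assay, and no step can be read between them. The series as a whole stands as follows: the limit of > 10 ug/mL in this assay, at which 3 of the 4 values shown sit. The compounds shown leave open how far compound 3 and compound 4 lie past that limit, and whether methoxy to ethoxy changes this read-out at all.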